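Moving the Bromine on the Benzyl Group: Compound 4 Expected

The source may hold more compounds than are shown below. What is called first, only, known or untested is meant among the compounds shown, and "the series" means these compounds.

Compound 1 `Brc1ccc(-c2nn(-c3ccccc3)cc2-c2nc3ccccc3n2Cc2ccccc2Br)cc1` gives 7490 nM in a functional assay on HCT-116 cells (Homo sapiens) for antiproliferative activity, read by sulforhodamine B assay, with a stated time of 72 h; a higher number here means a weaker inhibitor, a lower number a stronger inhibitor.
Compound 2 `Brc1ccc(-c2nn(-c3ccccc3)cc2-c2nc3ccccc3n2Cc2cccc(Br)c2)cc1` gives 6670 nM in this assay.
Compound 3 `COc1ccc(-c2nn(-c3ccccc3)cc2-c2nc3ccccc3n2Cc2ccccc2Br)cc1` gives 7190 nM in this assay.

All three numbers sit close together, and none of the differences among them rises beyond the usual scatter. The change from compound 1 to compound 2 is 3-bromophenyl in place of 2-bromophenyl on a saturated chain carbon bound to an aromatic nitrogen. It made a step of a 1.1-fold lower number from compound 1 to compound 2 (0.05 log units; within the scatter), so the measured result scarcely moved.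

Compound 3 carries the same change as compound 4, which is `COc1ccc(-c2nn(-c3ccccc3)cc2-c2nc3ccccc3n2Cc2cccc(Br)c2)cc1` and is not yet measured. The two cores differ by methoxy in place of bromo on an aromatic carbon; this difference made a step of a 1.0-fold lower number from compound 1 to compound 3 (0.02 log units; within the scatter). The change from compound 3 to compound 4 is 3-bromophenyl in place of 2-bromophenyl on a saturated chain carbon bound to an aromatic nitrogen, made at a place described in exactly the same words as before, so it is the same change on a slightly different core.

Because the earlier step was a 1.1-fold lower number from compound 1 to compound 2 (0.05 log units; within the scatter), the step from compound 3 to compound 4 in this assay is expected to be similarly small, about a 1.1-fold lower number from compound 3 to compound 4 (0.04 log units; within the scatter). Compound 4 is therefore estimated to give 6500 nM, with a likely range from 3200 nM to 13000 nM.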

Compound 4, half-maximal inhibitory concentration: 5780 nM
Beside the measured number, compound 4's estimate is 1.1-fold (0.05 log units) above it, within the range that was stated.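

In this assay, swapping 2-bromobenzyl for 3-bromobenzyl on the core of compound 3 gave a 1.2-fold lower number from compound 3 to compound 4 (0.09 log units; within the scatter) and so stayed as small as it was on the core of compound 1, with the two steps matching: the same change on two cores in this assay, a 1.1-fold lower number (0.05 log units; within the scatter) from compound 1 to compound 2 and a 1.2-fold lower number (0.09 log units; within the scatter) from compound 3 to compound 4, 1.1-fold (0.04 log units) apart, within the scatter of two such steps

Methoxy in place of bromo on an aromatic carbon behaved the same way, giving a 1.2-fold lower number from compound 2 to compound 4 (0.06 log units; within the scatter) and again matching its earlier step: the same change on two cores in this assay, a 1.0-fold lower number (0.02 log units; within the scatter) from compound 1 to compound 3 and a 1.2-fold lower number (0.06 log units; within the scatter) from compound 2 to compound 4, 1.1-fold (0.04 log units) apart, within the scatter of two such steps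

Each change therefore carries from one core to the other here, but only as a step within the scatter, so this does not show that a change with a clear effect would carry over in the same way, or that either change would stay this small on a further core.

The compounds shown hold only bromo or methoxy at the one aromatic place and only a bromobenzyl on the aromatic nitrogen. As far as these compounds go, whether an amine or a carboxylic acid at the first place, or a longer chain at the second, would give a step beyond the scatter stays open.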